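The source may report more compounds than this note shows. Statements on the series, on what has been measured and on what is new or still open speak of the compounds shown alone.

Working notes on the series, read in a functional assay on the whole organism with Rattus norvegicus as the target; on this read-out lower numbers stand for an effect already at smaller amounts and higher numbers for an effect only at larger amounts of compound. Compound 1 (`CCOC(=O)C(=O)Nc1ccc(N(C)C)cc1C#N`) gives 1 mg/kg, and compound 2 (`CCOC(=O)C(=O)Nc1cccc(NC)c1C#N`) gives 0.2 mg/kg. Compound 2 therefore holds the lower of the two numbers, and the gap to compound 1 lies beyond the scatter. The two compounds differ in more than one place, so this gap is not a clean step and says nothing firm about any single group.

Next in line is compound 3 (`CCOC(=O)C(=O)Nc1cccc(N2CCCCC2)c1C#N`), which carries piperidin-1-yl in place of methylamino on an aromatic carbon, ortho to a cyano group: piperidin-1-yl in place of methylamino on an aromatic carbon. Within the data shown here, no measured pair isolates a change at this position, so any expectation in this assay is a loose one. Compound 2 at 0.2 mg/kg already has the lower number, and compound 1 at 1 mg/kg is the only gauge of how far a number can move in this series. The estimated step of a 4.0-fold higher number from compound 2 to compound 3 (0.60 log units; beyond the scatter) is a moderate one toward a higher number, although no change beyond the scatter remains possible. The estimate for compound 3 is 0.8 mg/kg, with an expected range of 0.2 mg/kg to 3.5 mg/kg.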

Compound 3, dose for half-maximal effect: 2.2 mg/kg
The estimate for compound 3 lay 2.8-fold (0.44 log units) below the measured number; the range from low to high includes it.
By their numbers in this assay, from the lowest: compound 2; then compound 1; then compound 3.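

In this assay the aromatic carbon ortho to a cyano group now has its first clean step: piperidin-1-yl in place of methylamino gives an 11-fold higher number from compound 2 to compound 3 (1.04 log units; beyond the scatter), a large move that lies beyond the scatter. The number at this position therefore depends on the group it carries, and the earlier pair of compound 1 and compound 2, which differ in more than one place, could not show this. The change is a bundle, though: it adds heavy atoms, brings in a six-membered non-aromatic ring and leaves 0 hydrogen-bond donors on the entering group, and no measurement available ties the step to any one of these or gives a reason for it.

Among these compounds, the single step leaves open which part of the change carries the move, and whether the number follows the size of the group or the presence of the ring. Open-chain ethylamino, plain amino and a smaller ring such as azetidin-1-yl at the same place would begin to separate these readings.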